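Compound 3: furan-2-yl in place of methyl

A few compounds are considered here, and "the series" means these few. Any claim that something is new, unique, unknown or untested is made for them only; others in the source may bear on it.

Measured in an ADME assay on cells (Hepatocyte, Homo sapiens) for metabolic stability, with a stated time of 30 min; a higher number here means that more of the compound is left, a lower number that less of the compound is left:
Compound 1 `NC1CCC(CN2CCN(c3cc(=O)c4cc(C(F)(F)F)cc([N+](=O)[O-])c4s3)CC2)CC1` gives 83.6%
Compound 2 `CC(=O)OC1CCC(CN2CCN(c3cc(=O)c4cc(C(F)(F)F)cc([N+](=O)[O-])c4s3)CC2)CC1` gives 0%

Compound 2 holds the lower of these two numbers, and compound 1 stands well above it. For the measured compounds named here, the one measured step, with acetoxy in place of amino on a saturated ring carbon, is a number 83.6 percentage points lower from compound 1 to compound 2 (beyond the scatter) and lies beyond the scatter.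

Compound 3 `O=C(OC1CCC(CN2CCN(c3cc(=O)c4cc(C(F)(F)F)cc([N+](=O)[O-])c4s3)CC2)CC1)c1ccco1` keeps the shared core and has furan-2-yl in place of methyl on a carbonyl carbon, so that acetoxy becomes ((furan-2-yl)carbonyl)oxy. Going by the values given here, no measured step changes the group on that carbonyl carbon, so the data give no direct size for this change. The large step to compound 2 bears on it only indirectly, since compound 3 also lacks the amino group of compound 1. Compound 2 at 0% leaves room for movement in one direction only. The expected outcome is a number 5 percentage points higher from compound 2 to compound 3 (within the scatter) and no step beyond the scatter is anticipated. In this assay compound 3 is estimated at 5% with 0% to 20% as its expected range.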

Compound 3, percent of the compound remaining: 1%
Estimate against measurement, compound 3: 4 percentage points above, within the range that was stated.
By their numbers in this assay, from the lowest: compounds 2 and 3 (each within the scatter of the next); then compound 1.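

Furan-2-yl in place of methyl on a carbonyl carbon gives a number 1 percentage points higher from compound 2 to compound 3 (within the scatter) in this assay, so this larger ring-bearing group and the methyl cannot be told apart at this position. Swapping the amino group for ((furan-2-yl)carbonyl)oxy gives a number 82.6 percentage points lower from compound 1 to compound 3 (beyond the scatter), a large step like the one seen with acetoxy, so the large drop from compound 1 is no longer tied to acetoxy alone. No evidence is available on what lies behind either step.

Compound 2 and compound 3 both lie at the very bottom of the range of this assay, which leaves open whether any other group on that carbonyl carbon, such as a phenyl ring or a tert-butyl group, would give a different number. As far as these compounds go, it also remains open where a hydroxyl group, an amide or a carboxylic acid on the saturated ring carbon would fall in the wide gap between compound 1 and these two compounds.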